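This account rests on a few compounds, and the source may have more. Where it says the series, first, only, none or still open, it means among the compounds named here.

Measured in a functional assay on the whole organism (strain Wistar Albino) for inhibition, with Rattus norvegicus as the target, read by paw edema, with a stated time of 3 h, at a dose of 20 mg/kg; on this read-out higher numbers stand for more inhibition at the one dose given (going by the name of the read-out) and lower numbers for less inhibition:
compound 1 `COc1ccc(Cl)c(-c2nnc3sc(Cc4c[nH]c5ccc(OC)cc45)nn23)c1` gives 21.4%
compound 2 `COc1ccc(Cc2nnc3n2NC(c2ccco2)S3)cc1OC` gives 21.1%
compound 3 `COc1ccc(Cl)c(-c2nnc3n2NC(c2cccn2C)S3)c1` gives 18.5%

Compound 2 stands second highest of these three numbers, but its nearest neighbour, compound 1, lies within the scatter of it, as does its furthest neighbour, compound 3, so the three cannot be set in order. Compound 4 `COc1ccc(Cc2nnc3n2NC(c2cccn2C)S3)cc1OC` has not yet been tested. It differs from compound 2 by 1-methyl-1H-pyrrol-2-yl in place of furan-2-yl on a saturated ring carbon. Compound 3 also bears a 1-methyl-1H-pyrrol-2-yl group, and its value and that of compound 2 lie within the scatter of each other, so no step beyond the scatter is expected from compound 2 to compound 4 in this assay. Compound 4 is estimated to give 20% in this assay, with a range from 13% to 27%, which means an expected step of a number 1.1 percentage points lower from compound 2 to compound 4 (within the scatter).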

Compound 4, a percentage reported as inhibition, in the whole organism at one dose (the size of the read-out at that dose, not a potency): 18.4%
Estimate against measurement, compound 4: 1.6 percentage points above; the measured number falls inside the stated range.
By their numbers in this assay, from the lowest: compounds 4, 3, 2 and 1 (each within the scatter of the next).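

In this assay, among the compounds shown here, this is the first change at the saturated ring carbon that can be read on its own, with the rest of compound 2 left as it is, and it comes to a number 2.7 percentage points lower from compound 2 to compound 4 (within the scatter). On this read-out, then, the two five-membered aromatic rings at this position cannot be told apart. Nothing available bears on a cause for the step.

The compounds shown carry only these two rings at this carbon. From the compounds shown here alone, whether an amine or a carboxylic acid there would give a step beyond the scatter remains open.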